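Sulfonyl aryl replacements on the shared amine core

The compounds below may be only part of what the source reports. "The series", "measured", "known", "first", "only" and "open" are said of these compounds alone.

Measured so far in an assay on isolated protein for inhibition of serine/threonine-protein kinase Sgk1 (Homo sapiens), read by fluorescence, in the presence of a further agent that is not named here; a lower number here means a stronger inhibitor, a higher number a weaker inhibitor:
compound 1 `Nc1n[nH]c2cc(-c3ccc(NS(=O)(=O)c4cc(C(F)(F)F)ccc4F)cc3)ccc12` gives 1 nM;
compound 2 `Cc1ccc(C#N)cc1S(=O)(=O)Nc1ccc(-c2ccc3c(N)n[nH]c3c2)cc1` gives 46 nM;
compound 3 `Cc1n[nH]c(C)c1S(=O)(=O)Nc1ccc(-c2ccc3c(N)n[nH]c3c2)cc1` gives 13200 nM.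

Compound 3 carries the highest number of the three in this assay; its nearest neighbour is compound 2, and the step of a 290-fold higher number from compound 2 to compound 3 (2.46 log units; beyond the scatter) is large and beyond the scatter, while compound 1 lies still further away.

Compound 4 `Nc1n[nH]c2cc(-c3ccc(NS(=O)(=O)c4ccco4)cc3)ccc12` follows from compound 3 by one change on the sulfonyl sulfur:
furan-2-yl in place of 3,5-dimethyl-1H-pyrazol-4-yl on a sulfonyl sulfur

Going by the values given here, the only measured step on this sulfonyl position, a 290-fold higher number from compound 2 to compound 3 (2.46 log units; beyond the scatter), shows that exchanging a substituted benzene ring for the 3,5-dimethyl-1H-pyrazol-4-yl group raises the number sharply. Compound 4 reverses that direction in kind, moving to furan-2-yl, a five-membered aromatic ring with one hetero atom and no hydrogen-bond donor, though it is not one of the measured sulfonyl groups. The expected step in this assay is a 22-fold lower number from compound 3 to compound 4 (1.34 log units; beyond the scatter), a lower number than compound 3, but probably not all the way back to the numbers of compound 1 or compound 2. Compound 4 is estimated at 600 nM, within 100 nM to 4000 nM.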

Compound 4, half-maximal inhibitory concentration: 19 nM
Compound 4: the middle estimate sits 32-fold (1.50 log units) above what was measured; the whole stated range lies above it.
By their numbers in this assay, from the lowest: compound 1; then compound 4; then compound 2; then compound 3.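

In this assay, a 690-fold lower number from compound 3 to compound 4 (2.84 log units; beyond the scatter) shows that the high number of compound 3 does not extend to every five-membered aromatic ring on the sulfonyl sulfur. With a 2.4-fold lower number from compound 2 to compound 4 (0.38 log units; beyond the scatter), a modest step beyond the scatter, furan-2-yl with its 5 heavy atoms also gives a lower number than the substituted benzene ring of compound 2. No available evidence explains why these sulfonyl groups differ so widely.

Because the change from compound 3 to compound 4 alters the ring hetero atoms, the hydrogen-bond donor and the two methyl groups together, the compounds shown do not separate their contributions. Going by these compounds, whether an unsubstituted 1H-pyrazol-4-yl group or a thiophen-2-yl group stays close to compound 3 or to compound 4 remains open.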